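Shifting the Bromine to a 2-Bromobenzyl Group

The source may hold more compounds than are shown below. What is called first, only, known or untested is meant among the compounds shown, and "the series" means these compounds.

Compound 1 `Cc1cc(Nc2cc(-c3ccccc3)[nH]n2)n2nc(SCc3ccc(Br)cc3)nc2n1` gives 1110 nM
Compound 2 `Cc1cc(Nc2cc(-c3ccccc3)[nH]n2)n2nc(SCc3cccc(Br)c3)nc2n1` gives 4820 nM

In a functional assay on MGC-803 cells (Homo sapiens) for inhibition, read by MTT assay, with a stated time of 72 h (on this read-out lower numbers stand for stronger inhibition and higher numbers for weaker inhibition), compound 2 gives 4820 nM as the higher of the two numbers. Compound 3 `Cc1cc(Nc2cc(-c3ccccc3)[nH]n2)n2nc(SCc3ccccc3Br)nc2n1` differs from it thus: 2-bromophenyl in place of 3-bromophenyl on a saturated chain carbon bound to a sulfur and so carries 2-bromophenyl in place of 3-bromophenyl. Among the compounds with values here, the only measured step that bears on this is a 4.3-fold higher number from compound 1 to compound 2 (0.64 log units; beyond the scatter), which is modest and shows nothing about 2-bromophenyl, so no direction can be firmly expected. The estimated step is a 1.2-fold lower number from compound 2 to compound 3 (0.08 log units; within the scatter) and is expected to stay small. Compound 3 is expected at 4000 nM on this estimate, with a range from 1200 nM to 12000 nM as the expected span.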

Compound 3, half-maximal inhibitory concentration: 3650 nM
Compound 3: the middle estimate sits 1.1-fold (0.04 log units) above what was measured; the measured number falls inside the stated range.
By their numbers in this assay, from the lowest: compound 1; then compounds 3 and 2 (each within the scatter of the next).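

The 2-bromobenzyl group shows that neither other placing of the bromine matches the 4-bromobenzyl group of compound 1: this assay gives a 3.3-fold higher number from compound 1 to compound 3 (0.52 log units; beyond the scatter). The record between the remaining two is a 1.3-fold lower number from compound 2 to compound 3 (0.12 log units; within the scatter), so compound 2 and compound 3 cannot be told apart here. Nothing available explains why the place of the bromine matters. As far as these compounds go, it remains open whether an amine or a carboxylic acid in place of the bromine of the 4-bromobenzyl group would keep the number of compound 1.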